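A few compounds are considered here, and "the series" means these few. Any claim that something is new, unique, unknown or untested is made for them only; others in the source may bear on it.

In a functional assay on St-4 cells (Homo sapiens) for inhibition, read by sulforhodamine B assay, with a stated time of 48 h (on this read-out higher numbers stand for weaker inhibition of growth and lower numbers for stronger inhibition of growth), compound 1 (`CCCCCCCCCCCC[C@@H](O)[C@H]1CC[C@H]([C@H](O)CCCCCCCCCCN(C)C(=O)c2ccnn2C)O1`) gives 6760 nM and compound 2 (`CCCCCCCCCCCC[C@@H](O)[C@H]1CC[C@H]([C@H](O)CCCCCCCCCCNCc2ccnn2C)O1`) gives 1820 nM. Compound 2 therefore holds the lower of the two numbers, and so the stronger inhibition of growth. Compound 3 (`CCCCCCCCCCCC[C@@H](O)[C@H]1CC[C@H]([C@H](O)CCCCCCCCCCC(=O)Nc2ccnn2C)O1`) departs from compound 2 at the end of the chain: (1-methyl-1H-pyrazol-5-yl)carbamoyl in place of ((1-methyl-1H-pyrazol-5-yl)methyl)amino on a saturated chain carbon, ten or more bonds along the chain from an oxygen on a saturated carbon and a saturated ring carbon. Within the data shown here, only one measured step bears on this change, namely a 3.7-fold lower number from compound 1 to compound 2 (0.57 log units; beyond the scatter), in which an amide carbonyl is lost and the number falls. Among the measured compounds shown here, compound 3 brings a carbonyl back, as (1-methyl-1H-pyrazol-5-yl)carbamoyl, although no measured compound carries that group. A rise of modest size, similar to that step in reverse, is therefore expected in this assay, with weaker inhibition of growth as the outcome. The expected change is a 2.7-fold higher number from compound 2 to compound 3 (0.44 log units; beyond the scatter). For compound 3 the estimated value is 5000 nM, with a range of 2000 nM to 12000 nM.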

Compound 3, concentration for 50% growth inhibition: 100000 nM
The estimate for compound 3 lay 20-fold (1.30 log units) below the measured number; the measured number lies above the stated range.
By their numbers in this assay, from the lowest: compound 2; then compound 1; then compound 3.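

In this assay, among these compounds, this end of the chain proves far more sensitive than the single earlier step could show, with a 55-fold higher number from compound 2 to compound 3 (1.74 log units; beyond the scatter) and, against the other amide, a 15-fold higher number from compound 1 to compound 3 (1.17 log units; beyond the scatter). The presence of a carbonyl therefore does not set the outcome on its own: compound 1 and compound 3 both carry one, yet the (1-methyl-1H-pyrazol-5-yl)carbamoyl group gives much weaker inhibition of growth than methyl((1-methyl-1H-pyrazol-5-yl)carbonyl)amino. Nothing available explains this gap.

The compounds shown leave open whether a tertiary amine, with a methyl group on the nitrogen of ((1-methyl-1H-pyrazol-5-yl)methyl)amino, would keep the number of compound 2. They also do not tell how a longer chain between that nitrogen and the pyrazole ring, or a simple carboxylic acid at the chain end, would read.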